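Aryl substituent swap on the shared core: first estimate

The source may hold more compounds than are shown below. What is called first, only, known or untested is meant among the compounds shown, and "the series" means these compounds.

Measured so far:
compound 1, `CC(=O)OC[C@H]1O[C@@H](n2cc(CN3C(=O)/C(=C/c4ccc(C)cc4)c4ccccc43)nn2)[C@H](OC(C)=O)[C@@H](OC(C)=O)[C@@H]1OC(C)=O`: 85600 nM
compound 2, `CC(=O)OC[C@H]1O[C@@H](n2cc(CN3C(=O)/C(=C\c4ccc(C)cc4)c4ccccc43)nn2)[C@H](OC(C)=O)[C@@H](OC(C)=O)[C@@H]1OC(C)=O`: > 100000 nM

Among the compounds with values here, in a functional assay on HeLa cells (Homo sapiens) for cytotoxicity, read by sulforhodamine B assay, with a stated time of 48 h (a lower number here means a stronger inhibitor, a higher number a weaker inhibitor), compound 1 gives 85600 nM, the only number measured. Compound 2 returns only a limit of the assay, > 100000 nM, not a number. The step of an at least 1.1-fold higher number from compound 1 to compound 2 (0.06 log units; that floor lies within the scatter) cannot be sized beyond its floor because of the limit of > 100000 nM in this assay, at which 1 of the 2 values shown sits; it concerns only geometry, because of the fact that compounds 1 and 2 differ only in the configuration as drawn, and so says nothing about the aryl substituent.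

Compound 3, `CC(=O)OC[C@H]1O[C@@H](n2cc(CN3C(=O)/C(=C/c4ccc(N(C)C)cc4)c4ccccc43)nn2)[C@H](OC(C)=O)[C@@H](OC(C)=O)[C@@H]1OC(C)=O`, differs from compound 1 by dimethylamino in place of methyl on an aromatic carbon. Within the data shown here, no measured pair changes the group on the 4-methylphenyl ring, so no measured step bears on this change; the two numbers available both sit at the weak end of this assay. With nothing to point either way, compound 3 is expected to stay within the scatter of compound 1, a step of a 1.0-fold lower number from compound 1 to compound 3 (0.00 log units; within the scatter). The estimate for compound 3 in this assay is 85000 nM, with a range of 30000 nM to 250000 nM, and a real chance that only a limit is returned.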

Compound 3, half-maximal inhibitory concentration: 26300 nM
Estimate against measurement, compound 3: 3.2-fold (0.51 log units) above; measured number outside the range, below it.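

In this assay, the position on the aromatic ring para to a large group responds to its substituent: dimethylamino in place of methyl gives a 3.3-fold lower number from compound 1 to compound 3 (0.51 log units; beyond the scatter). Within the data shown here, this is the first step that concerns the aryl substituent and can be sized, and although it is modest, it shows that this position is not silent in this assay, with the shared core, the E double bond and the acetylated sugar all left unchanged. Nothing recorded for this series gives a measured property that would account for the step.

Among these compounds, the single change replaces methyl with a larger group that also brings in a nitrogen, so these compounds cannot separate the contribution of the nitrogen from that of the added carbons, and a comparison with an ethyl, an isopropyl, a methoxy or a primary amine at the same place would be needed to tell them apart. Also open, going by these compounds, are whether a carboxylic acid or a longer chain here would move the number further, and whether the step holds with the double bond drawn Z.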